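A few compounds are considered here, and "the series" means these few. Any claim that something is new, unique, unknown or untested is made for them only; others in the source may bear on it.

Measured in an ADME assay on the whole organism (strain Sprague-Dawley) for pharmacokinetics, with Rattus norvegicus as the target, using cassette dosing, at a dose of 1 mg/kg by the oral route; on this read-out lower numbers stand for lower oral bioavailability and higher numbers for higher oral bioavailability:
- compound 1 `O[C@]1(Cc2cc(-c3cn[nH]c3)on2)CC[C@H](Cc2ccccc2)CC1`: 46.3%
- compound 2 `O[C@]1(Cc2cc(-c3cn[nH]c3)on2)CC[C@H](Cc2ccc(F)cc2)CC1`: 78%
- compound 3 `O[C@]1(Cc2cc(-c3cn[nH]c3)on2)CC[C@H](Cc2ccc(OC(F)(F)F)cc2)CC1`: 121%

Compound 2 stands second highest of the three, with compound 1 lower and compound 3 higher. The next analogue, compound 4 `O[C@]1(Cc2cc(-c3cn[nH]c3)on2)CC[C@H](Cc2ccc(F)c(F)c2)CC1`, carries a 3,4-difluorobenzyl group in place of the 4-fluorobenzyl group of compound 2: fluoro in place of hydrogen on an aromatic carbon. This is fluoro in place of hydrogen on an aromatic carbon, ortho to a fluoro group and meta to a large group.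

Within the data shown here, the nearest precedent is the same kind of replacement, a number 31.7 percentage points higher from compound 1 to compound 2 (beyond the scatter). The change to trifluoromethoxy gave a number 74.7 percentage points higher from compound 1 to compound 3 (beyond the scatter), and replacing fluoro with that group gave a number 43 percentage points higher from compound 2 to compound 3 (beyond the scatter). All three steps were large and upward, and none of the three compounds goes against that direction. Among the measured compounds shown here, no measured step, however, adds a second group to the ring, so a smaller gain seems likelier than a repeat of those steps. A modest upward change is expected, a number 12 percentage points higher from compound 2 to compound 4 (beyond the scatter). For compound 4 the estimated value in this assay is 90%, with an expected range from 65% to 115%.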

Compound 4, oral bioavailability: 67.5%
Compound 4: the middle estimate sits 22.5 percentage points above what was measured; low and high end bracket the measured number.
By their numbers in this assay, from the lowest: compound 1; then compound 4; then compound 2; then compound 3.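

In this assay, fluoro in place of hydrogen on an aromatic carbon does not always raise the number: ortho to a fluoro group, the change gives a number 10.5 percentage points lower from compound 2 to compound 4 (beyond the scatter), the first downward step among these compounds, against the upward step of the same kind from compound 1 to compound 2. The 3,4-difluorobenzyl group still keeps a gain over the unsubstituted benzyl group, with a number 21.2 percentage points higher from compound 1 to compound 4 (beyond the scatter), so the second fluoro gives back only part of what the first one added. Nothing available accounts for this reversal.

On these data alone, it remains open whether the drop comes with any second group on this ring or with fluoro in particular. A chloro or methoxy group ortho to a fluoro group would separate these two readings.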